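Changing the Two-Ring Group on the Amide Carbonyl

The compounds below may be only part of what the source reports. "The series", "measured", "known", "first", "only" and "open" are said of these compounds alone.

In an assay for inhibition of Nicotinamide phosphoribosyltransferase (Homo sapiens), read by mass spectrometry, with stated times of 15 min and 30 min (on this read-out higher numbers stand for weaker inhibition and lower numbers for stronger inhibition), compound 3 `O=C(NCc1ccc(S(=O)(=O)c2cccc(C(F)(F)F)c2)cc1)c1cnc2nccn2c1` gives 1 nM, the lowest number among the three measured compounds. Compound 2 `O=C(NCc1ccc(S(=O)(=O)c2cccc(C(F)(F)F)c2)cc1)c1cc2ccncc2o1` gives 5 nM, and compound 1 `O=C(NCc1ccc(S(=O)(=O)c2ccccc2)cc1)c1ccc2nccn2c1` gives 18 nM. Compound 4 `O=C(NCc1ccc(S(=O)(=O)c2cccc(C(F)(F)F)c2)cc1)c1ccc2nccn2c1` differs from compound 3 by a group of 9 heavy atoms (7 carbon, 2 nitrogen; one five-membered aromatic ring with 2 hetero atoms, one six-membered aromatic ring with 1 hetero atom) in place of a group of 9 heavy atoms (6 carbon, 3 nitrogen; one five-membered aromatic ring with 2 hetero atoms, one six-membered aromatic ring with 2 hetero atoms), on a carbonyl carbon. For the measured compounds named here, the only measured step at this position is a 5.0-fold lower number from compound 2 to compound 3 (0.70 log units; beyond the scatter), which exchanges a different pair of two-ring groups; it shows that this position matters, but it does not cover the present swap. Going by the values given here, compound 1 carries the same entering group as compound 4 yet lacks the trifluoromethyl, and no step for that pair is known. Compound 4 is therefore expected at 4 nM, within 1.5 nM to 12 nM, a step of a 4.0-fold higher number from compound 3 to compound 4 (0.60 log units; beyond the scatter) toward a weaker number.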

Compound 4, half-maximal inhibitory concentration: 8 nM
For compound 4 the middle estimate is 2.0-fold (0.30 log units) below the measured one; the range from low to high includes it.
By their numbers in this assay, from the lowest: compound 3; then compounds 2 and 4 (each within the scatter of the next); then compound 1.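

In this assay, replacing the six-membered aromatic ring with 2 hetero atoms by one with 1 hetero atom gives a change beyond the scatter (an 8.0-fold higher number from compound 3 to compound 4 (0.90 log units; beyond the scatter)), so one ring atom in this group matters. The two groups compared in the next step cannot be told apart (a 1.6-fold higher number from compound 2 to compound 4 (0.20 log units; within the scatter)). The first step away from this position, trifluoromethyl in place of hydrogen on an aromatic carbon, also changes the number (a 2.3-fold lower number from compound 1 to compound 4 (0.35 log units; beyond the scatter)). No measurement here explains these steps. From the compounds shown here alone, whether a chlorine in place of trifluoromethyl, or an amine on the two-ring group, would change the number remains open.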